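Nitro in place of fluoro: a series with one number

The source may hold more compounds than are shown below. What is called first, only, known or untested is meant among the compounds shown, and "the series" means these compounds.

Of the compounds shown here, two have been measured so far in a functional assay on Bel7402/5-FU cells (Homo sapiens) for cytotoxicity, read by MTT assay, with a stated time of 72 h; a higher number here means a weaker inhibitor, a lower number a stronger inhibitor. Compound 1 `O=C1C=CCC/C1=C\C(Br)=C\c1ccccc1` gives > 10000 nM, which is a limit of the assay and not a number. Among the compounds with values here, compound 2 `O=C1C=CCC/C1=C\C=C\c1ccc(F)cc1` gives 1900 nM, the only actual number.

Compound 3 `O=C1C=CCC/C1=C\C=C\c1ccc([N+](=O)[O-])cc1` keeps the rest of compound 2 and carries nitro in place of fluoro on an aromatic carbon, para to a large group (nitro in place of fluoro on an aromatic carbon). Within the data shown here, no measured pair differs in one place only, so the data offer no direct precedent for this change. In this assay, the expectation is therefore a small shift, perhaps towards a slightly stronger inhibitor, or none beyond the scatter. The estimate is anchored on compound 2 at 1900 nM. The expected step is a 1.3-fold lower number from compound 2 to compound 3 (0.10 log units; within the scatter). For compound 3, the estimated value is 1500 nM, with an expected range of 400 nM to 6500 nM.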

Compound 3, half-maximal inhibitory concentration: 4500 nM
Estimate against measurement, compound 3: 3.0-fold (0.48 log units) below; measured number inside the range.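

In this assay the series now holds its first comparison of compounds that differ in one place: nitro in place of fluoro on an aromatic carbon, para to a large group, gives a 2.4-fold higher number from compound 2 to compound 3 (0.37 log units; beyond the scatter). The earlier compounds shown here could not show whether this aromatic carbon responds to a change of group at all; this single step shows that, for this pair, the exchange moves the number beyond the usual scatter, though only modestly. Compound 3 still gives a measured number, whereas the only value in the series that is a limit and not a number belongs to compound 1, which differs from compound 3 in more than one place and so offers no step at this position: the limit of > 10000 nM in this assay, at which 1 of the 3 values shown sits.

One step cannot show whether the higher number reflects the arrival of nitro or the departure of fluoro, and it gives no trend across groups at this carbon. From the compounds shown here alone, whether a chloro group, a methoxy group or an amine in the same place would read closer to compound 2 or to compound 3 remains open.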